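Swapping a Single Halogen on the Sulfonyl Aryl Group

The source may report more compounds than this note shows. Statements on the series, on what has been measured and on what is new or still open speak of the compounds shown alone.

Compound 1, `Cc1ccc(S(=O)(=O)c2cnc3cc(F)ccc3c2N2CCC(C)CC2)cc1C`: 90%
Compound 2, `CC1CCN(c2c(S(=O)(=O)c3ccc(F)c(Cl)c3)cnc3cc(Cl)ccc23)CC1`: 94%
Compound 3, `CC1CCN(c2c(S(=O)(=O)c3ccc(Cl)c(Cl)c3)cnc3cc(F)ccc23)CC1`: 94%

Three compounds sharing one core were tested in an assay on isolated protein for displacement of a labelled ligand from metabotropic glutamate receptor 5 (Homo sapiens), with a stated time of 60 min, tested at 1 uM; on this read-out lower numbers stand for less inhibition and higher numbers for more inhibition at the one concentration tested (going by the name of the read-out). Compound 3 gives 94%, level at the digits printed with compound 2 at 94%, and together these are the highest of the three numbers; compound 1 at 90% differs from them only within the scatter. Among the measured compounds shown here, the one step measured is a number 4 percentage points higher from compound 1 to compound 3 (within the scatter), a change within the scatter. Compound 4, `CC1CCN(c2c(S(=O)(=O)c3ccc(F)c(Cl)c3)cnc3cc(F)ccc23)CC1`, differs from compound 3 by a smaller change: fluoro in place of chloro on an aromatic carbon. For the measured compounds named here, no measured step isolates this swap on its own; compound 2 carries the same 3-chloro-4-fluorophenyl group on a core that differs by one halogen. Since the larger aryl exchange moved nothing beyond the scatter, compound 4 is expected to stay at a similar level, a number 1 percentage points lower from compound 3 to compound 4 (within the scatter), with an estimated 93% and a range from 85% to 98%.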

Compound 4, a percentage reported as inhibition, at one concentration (the size of the read-out at that concentration, not a potency): 94%
Compound 4: the middle estimate sits 1 percentage points below what was measured; the range from low to high includes it.
By their numbers in this assay, from the lowest: compounds 1, 2, 3 and 4 (each within the scatter of the next).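

In this assay, 3-chloro-4-fluorophenyl in place of 3,4-dichlorophenyl gives no change at the digits printed from compound 3 to compound 4 (within the scatter), so fluoro and chloro at this carbon, para to a large group, cannot be told apart at the one concentration tested. The same swap on the shared core gives no change at the digits printed from compound 2 to compound 4 (within the scatter), and 3-chloro-4-fluorophenyl in place of 3,4-dimethylphenyl gives a number 4 percentage points higher from compound 1 to compound 4 (within the scatter). Nothing available explains these results. Going by these compounds, whether a methoxy group or an amine at this carbon would give a different number remains open.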